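Piperidinylmethyl extension of the crotonamide chain in compound 4

A few compounds are considered here, and "the series" means these few. Any claim that something is new, unique, unknown or untested is made for them only; others in the source may bear on it.

Measured so far in a functional assay on PC-3 cells (Homo sapiens) for antiproliferative activity, read by MTT assay, with a stated time of 72 h; on this read-out higher numbers stand for weaker inhibition and lower numbers for stronger inhibition:
compound 1 `C/C=C/C(=O)Nc1cc2c(N3CCCc4ccccc43)ncnc2cc1OC` gives 7520 nM;
compound 2 `C/C=C/C(=O)Nc1cc2c(N3CCCc4ccccc43)ncnc2cc1O[C@@H]1CCOC1` gives 9350 nM;
compound 3 `CN1CCN(C/C=C/C(=O)Nc2cc3c(N4CCc5ccccc54)ncnc3cc2O[C@@H]2CCOC2)CC1` gives 4210 nM.

Compound 1 stands second highest of the three numbers, and its gap to both compound 2 and compound 3 lies within the scatter. Within the data shown here, the only single-place step recorded, a 1.2-fold higher number from compound 1 to compound 2 (0.09 log units; within the scatter), concerns the aryl ether and has no bearing on the chain. Compound 4 `COc1cc2ncnc(N3CCCc4ccccc43)c2cc1NC(=O)/C=C/CN1CCC(CO)CC1` differs from compound 1 by 4-(hydroxymethyl)piperidin-1-yl in place of hydrogen on a saturated chain carbon bound to a double-bonded chain carbon. Among the measured compounds shown here, no measured step isolates an amine on this chain carbon; compound 3, which carries one together with a second change, sits within the scatter of compound 2. The change is therefore expected to give at most a step within the scatter, a 1.5-fold lower number from compound 1 to compound 4 (0.18 log units; within the scatter), and compound 4 is estimated at 5000 nM (range 2000 nM to 15000 nM).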

Compound 4, half-maximal inhibitory concentration: 7150 nM
The estimate for compound 4 lay 1.4-fold (0.16 log units) below the measured number; measured number inside the range.
By their numbers in this assay, from the lowest: compounds 3, 4, 1 and 2 (each within the scatter of the next, the first and the last beyond it).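

Placing 4-(hydroxymethyl)piperidin-1-yl in place of hydrogen on a saturated chain carbon bound to a double-bonded chain carbon gives, in this assay, a 1.1-fold lower number from compound 1 to compound 4 (0.02 log units; within the scatter). Among these compounds, this is the only step here that isolates a cyclic amine on this carbon, and it shows that the position carries this large group with no shift beyond the scatter. No measurement on hand accounts for this result.

Still open, as far as these compounds go, is whether a dimethylamino group, a carboxylic acid or unsubstituted piperidin-1-yl on this carbon would give a number beyond the scatter.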